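Triple bond for double bond: expectation for compound 4

The compounds below may be only part of what the source reports. "The series", "measured", "known", "first", "only" and "open" are said of these compounds alone.

Compound 2 `CN(C)CCC(NC(=O)/C=C/c1ccccc1)c1ccc2ccccc2c1` gives 116% in a functional assay on NIH3T3 cells for agonist activity at Urotensin-2 receptor (Homo sapiens), with a stated time of 5 days (on this read-out lower numbers stand for smaller maximal responses and higher numbers for larger maximal responses), and stands second highest of the three numbers shown. Compound 1 `CN(C)CCC(NC(=O)/C=C/c1ccc(C(F)(F)F)cc1)c1ccc2ccccc2c1` gives 117% in this assay, the step being a number 1 percentage points lower from compound 1 to compound 2 (within the scatter). Compound 3 `COc1ccc(/C=C/C(=O)NC(CCN(C)C)c2ccc3ccccc3c2)cc1` gives 106% in this assay, the step being a number 10 percentage points lower from compound 2 to compound 3 (within the scatter). Compound 4 `CN(C)CCC(NC(=O)C#Cc1ccccc1)c1ccc2ccccc2c1` differs from compound 2 by 2-phenylethynyl in place of 2-phenylethenyl on a carbonyl carbon. Among the measured compounds shown here, no measured step touches this part of the molecule; the known steps all change a group on an aromatic carbon, the largest being a number 11 percentage points lower from compound 1 to compound 3 (beyond the scatter), and they leave the series within a narrow band. For compound 4 a step of a number 6 percentage points lower from compound 2 to compound 4 (within the scatter) is therefore expected, nothing beyond the scatter. The estimate for compound 4 in this assay is 110%, with a range of 88% to 130%.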

Compound 4, largest response reached (reported as efficacy), in percent of the reference or control that the assay uses: 115%
Compound 4: the middle estimate sits 5 percentage points below what was measured; low and high end bracket the measured number.
By their numbers in this assay, from the lowest: compounds 3, 4, 2 and 1 (each within the scatter of the next, the first and the last beyond it).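

Among the compounds shown here, the step of a number 1 percentage points lower from compound 2 to compound 4 (within the scatter) in this assay is the first to touch the group on the carbonyl carbon rather than a group on an aromatic carbon. At this position, 2-phenylethynyl keeps the maximal response seen with 2-phenylethenyl, so the double bond is not required for it. No available data explain this result.

Still open, on these data alone, is whether a saturated 2-phenylethyl group or a longer chain on the carbonyl carbon would keep this response. Also open, as far as these compounds go, is how trifluoromethyl or methoxy on the aromatic ring of 2-phenylethynyl would behave.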